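The source may hold more compounds than are shown below. What is called first, only, known or untested is meant among the compounds shown, and "the series" means these compounds.

Measured compounds:
compound 1 `CCCCCCCCc1ccc(OCC(=O)Cn2nnc(-c3ccc(Cl)cc3)n2)cc1` — 74%
compound 2 `CCCCCCCCc1ccc(OC(C)C(=O)Cn2nnc(-c3ccc(Cl)cc3)n2)cc1` — 72%

In an ADME assay on S9 fraction from liver (Rattus norvegicus) for metabolic stability, read by LC-MS, using NADPH, with a stated time of 30 min (on this read-out higher numbers stand for a more stable compound and lower numbers for a less stable compound), compound 2 stands lowest of the two numbers, its nearest neighbour being compound 1, and the step of a number 2 percentage points lower from compound 1 to compound 2 (within the scatter) lies within the scatter. Compound 3 `CC(Oc1ccc(-c2ccccc2)cc1)C(=O)Cn1nnc(-c2ccc(Cl)cc2)n1` differs from compound 2 by phenyl in place of octyl on an aromatic carbon. Going by the values given here, no measured step concerns this change; the only step known touches a chain carbon, not the aromatic substituent, so no direction can be taken from it. Compound 3 is therefore expected to give about 70%, within a broad range from 45% to 90%. The step expected is a number 2 percentage points lower from compound 2 to compound 3 (within the scatter), not beyond the scatter.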

Compound 3, percent of the compound remaining: 18%
For compound 3 the middle estimate is 52 percentage points above the measured one; the measured number lies below the stated range.
By their numbers in this assay, from the lowest: compound 3; then compounds 2 and 1 (each within the scatter of the next).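

In this assay, going by these compounds alone, the aromatic carbon para to a large group proves sensitive to what it carries, which the earlier compounds could not show, as their only step lay at a chain carbon and within the scatter. Phenyl in place of octyl gives a number 54 percentage points lower from compound 2 to compound 3 (beyond the scatter), so this position cannot be treated as tolerant of any large group. Nothing at hand accounts for this drop. On these data alone, it remains open whether the entering ring or the departing chain matters more, and how a butyl chain or a cyclohexyl group would fare at this aromatic carbon.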